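The source may report more compounds than this note shows. Statements on the series, on what has been measured and on what is new or still open speak of the compounds shown alone.

Measured compounds:
- compound 1, `O=C(O)c1ccc(F)cc1-c1ccc2c(c1)OC[C@H](Cc1ccccc1)[C@H]2O`: 12 nM; 3 nM; 27 nM (3 entries)
- compound 2, `CC(C)c1ccc(C[C@H]2COc3cc(-c4cc(F)ccc4C(=O)O)ccc3[C@@H]2O)cc1`: 190 nM

Within the data shown here, in an assay on isolated protein for binding affinity to leukotriene B4 receptor (Homo sapiens) (a higher number here means a weaker inhibitor, a lower number a stronger inhibitor), compound 2 gives 190 nM, the only number it has there; compound 1 gives 12 nM; 3 nM; 27 nM (3 entries), and the several entries of compound 1 in this assay, 12 nM; 3 nM; 27 nM (3 entries) shows how much its repeats spread. On the numbers shown, compound 2 stands weaker than compound 1.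

Compound 3, `O=C(O)c1ccc(F)cc1-c1ccc2c(c1)OC[C@H](CCc1ccccc1)[C@H]2O`, is not yet measured. Its change from compound 2 is benzyl in place of 4-isopropylphenyl on a saturated chain carbon bound to a saturated ring carbon; read one bond further out, 4-isopropylbenzyl becomes phenethyl. Among the measured compounds shown here, no step between measured compounds matches it, so the size is open. Compound 3 ends up one chain carbon longer than compound 1 and without the 4-isopropyl group of compound 2, so it is expected to move back toward compound 1, with the step from compound 2 to compound 3 expected as a 6.3-fold lower number from compound 2 to compound 3 (0.80 log units; beyond the scatter). For compound 3 the expected value in this assay is 30 nM, in the range 8 nM to 120 nM.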

Compound 3, half-maximal inhibitory concentration: 35 nM
Estimate against measurement, compound 3: 1.2-fold (0.07 log units) below; measured number inside the range.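

In this assay, the group on a saturated chain carbon bound to a saturated ring carbon can go from 4-isopropylbenzyl to phenethyl with a 5.4-fold lower number from compound 2 to compound 3 (0.73 log units; beyond the scatter), so the number at this position depends on the group it carries. This one step joins two alterations, the loss of the 4-isopropyl group and one more chain carbon, and the pair alone cannot separate them. Compound 3 gives 35 nM as a single entry, which has to be read against the spread seen in compound 1: the several entries of compound 1 in this assay, 12 nM; 3 nM; 27 nM (3 entries).

On these data alone, whether a longer chain such as phenylpropyl holds this level stays open, as does the effect of 4-isopropylphenethyl, which would separate the two alterations. As far as these compounds go, what an amine in place of the isopropyl group would do also remains open.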